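The compounds below may be only part of what the source reports. "The series", "measured", "known", "first", "only" and "open" are said of these compounds alone.

- Compound 1 `CCn1ccc2cc(C(=O)c3cc(OC)c(OC)c(OC)c3)ccc21` gives 36 nM
- Compound 2 `COc1cc(C(=O)c2ccc3c(ccn3CC(=O)O)c2)cc(OC)c1OC` gives 520 nM

Both values come from a functional assay on KB cells (Homo sapiens) for inhibition, with a stated time of 72 h (on this read-out higher numbers stand for weaker inhibition and lower numbers for stronger inhibition), and they are the only two so far. Compound 2 holds the higher number of the pair, so it is the weaker inhibitor. Among the measured compounds shown here, the single measured step is a 14-fold higher number from compound 1 to compound 2 (1.16 log units; beyond the scatter) and it came with carboxy in place of methyl on a saturated chain carbon bound to an aromatic nitrogen.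

Compound 3 `COc1cc(C(=O)c2ccc3c(ccn3CCN(C)C)c2)cc(OC)c1OC` changes that same place: (dimethylamino)methyl in place of carboxy on a saturated chain carbon bound to an aromatic nitrogen gives (dimethylamino)methyl in place of carboxy, which also reads as carboxymethyl to 2-(dimethylamino)ethyl. The carboxy linked to the large step leaves, so a move back toward compound 1 (36 nM) is expected. For the measured compounds named here, only part of that way back is expected, since no measured compound carries the new group and one step is thin evidence. The estimated change, a lower number, is a 3.5-fold lower number from compound 2 to compound 3 (0.54 log units; beyond the scatter) in this assay and it is uncertain. Compound 3 is expected at 150 nM with an estimated range from 40 nM to 550 nM in this measurement.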

Compound 3, half-maximal inhibitory concentration: 5200 nM
Compound 3: middle estimate off by 35-fold (1.54 log units), on the low side; measured number above the stated range.
By their numbers in this assay, from the lowest: compound 1; then compound 2; then compound 3.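

Taking the carboxy away did not restore inhibition at this place: in this assay, the change from carboxymethyl to 2-(dimethylamino)ethyl gave a 10-fold higher number from compound 2 to compound 3 (1.00 log units; beyond the scatter) and moved the number further from that of compound 1. Set against the plain ethyl chain of compound 1, the dimethylamino on the chain gave a 140-fold higher number from compound 1 to compound 3 (2.16 log units; beyond the scatter) and so stands as the largest step in this small set. Among these compounds, then, the high number of compound 2 cannot be pinned on the carboxy alone, since two quite different groups on this chain both give weaker inhibition than plain ethyl, and the dimethylamino group gives the weakest of the three. Nothing measured here explains why either group raises the number.

The compounds shown leave open whether a chain ending in a hydroxyl or a methoxy group would stay close to compound 1 at 36 nM or would also lose inhibition. They also leave open how a shorter methyl group or a longer propyl chain would compare with the ethyl chain, and whether a primary amine or an amide at the chain end would behave like the dimethylamino group.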